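Propyl and Dimethyl Piperazine Variant of a Serotonin Ligand

The source may report more compounds than this note shows. Statements on the series, on what has been measured and on what is new or still open speak of the compounds shown alone.

Within the data shown here, compound 1 `COc1cc2c(cc1N1CCN(C)CC1)N(C(=O)c1ccc(-c3cccc(C)n3)c3ccccc13)CC2` gives 2 nM in an assay on isolated protein for binding affinity to 5-hydroxytryptamine receptor 1B (Homo sapiens) (on this read-out higher numbers stand for weaker inhibition and lower numbers for stronger inhibition), the lowest of the two numbers measured so far. Compound 2 `COc1cc2c(cc1N1C[C@@H](C)N(C)[C@@H](C)C1)N(C(=O)c1ccc(-c3cccc(C)n3)c3ccccc13)CC2` gives 3.16 nM in this assay, and the change a 1.6-fold higher number from compound 1 to compound 2 (0.20 log units; within the scatter) lies within the scatter. Compound 3 `CCCN1[C@H](C)CN(c2cc3c(cc2OC)CCN3C(=O)c2ccc(-c3cccc(C)n3)c3ccccc23)C[C@@H]1C` differs from compound 1 by 3,5-dimethyl-4-propylpiperazin-1-yl in place of 4-methylpiperazin-1-yl on an aromatic carbon. Among the measured compounds shown here, only the step from compound 1 to compound 2 bears on this change; it covers the two added methyl groups on the ring but not the propyl, so no step beyond the scatter is expected, with at most a slight lean toward a higher number. Compound 3 is expected to give 4 nM in this assay, in a range from 1.5 nM to 12 nM. The expected step is a 2.0-fold higher number from compound 1 to compound 3 (0.30 log units; within the scatter).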

Compound 3, inhibition constant: 31.6 nM
Estimate against measurement, compound 3: 7.9-fold (0.90 log units) below; the measured number lies above the stated range.
By their numbers in this assay, from the lowest: compounds 1 and 2 (each within the scatter of the next); then compound 3.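

The two added ring methyl groups of compound 2 stayed within the scatter, but at this aromatic carbon, ortho to the methoxy group, 3,5-dimethyl-4-propylpiperazin-1-yl gives in this assay a 16-fold higher number from compound 1 to compound 3 (1.20 log units; beyond the scatter) and thus a clear change. The further step, ethyl in place of hydrogen on the chain carbon, gives a 10-fold higher number from compound 2 to compound 3 (1.00 log units; beyond the scatter) and ties the higher number to the propyl rather than to the ring methyl groups alone. Nothing measured here accounts for this step.

From the compounds shown here alone, whether the propyl gives the same step on a piperazine without the two ring methyl groups remains open. So does how an ethyl or a cyclopropylmethyl group on that nitrogen would read.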